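Iodo and chloro additions on a naphthol benzothiazole series

The source may hold more compounds than are shown below. What is called first, only, known or untested is meant among the compounds shown, and "the series" means these compounds.

Measured so far:
compound 1 `Oc1ccc2ccccc2c1C(Nc1nc2ccccc2s1)c1cn(-c2ccccc2)nc1-c1ccccc1`: 48900 nM
compound 2 `Oc1ccc2ccccc2c1C(Nc1nc2ccccc2s1)c1cn(-c2ccccc2)nc1-c1ccc(I)cc1`: 18900 nM
compound 3 `Oc1ccc2ccccc2c1C(Nc1nc2ccc(Cl)cc2s1)c1cn(-c2ccccc2)nc1-c1ccccc1`: 36300 nM

All three compounds were tested in a functional assay on MCF7 cells (Homo sapiens) for antiproliferative activity, read by MTT assay, with a stated time of 48 h; a higher number here means a weaker inhibitor, a lower number a stronger inhibitor. Compound 2 differs from compound 1 by iodo in place of hydrogen on an aromatic carbon, and the step of a 2.6-fold lower number from compound 1 to compound 2 (0.41 log units; beyond the scatter) is the only one in the set that falls beyond the scatter. Compound 3 differs from compound 1 by chloro in place of hydrogen on an aromatic carbon, and the step of a 1.3-fold lower number from compound 1 to compound 3 (0.13 log units; within the scatter) stays within the scatter, so the two numbers cannot be ordered.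

Compound 4 `Oc1ccc2ccccc2c1C(Nc1nc2ccc(Cl)cc2s1)c1cn(-c2ccccc2)nc1-c1ccc(I)cc1` is not yet measured. It differs from compound 3 by iodo in place of hydrogen on an aromatic carbon, the same change that turned compound 1 into compound 2, made on the core of compound 3 rather than the core of compound 1. Among the compounds with values here, the starting point is compound 3 with 36300 nM, and the only measured instance of this change is a 2.6-fold lower number from compound 1 to compound 2 (0.41 log units; beyond the scatter). A step of similar size is expected for compound 4, a 2.6-fold lower number from compound 3 to compound 4 (0.41 log units; beyond the scatter). Compound 4 is therefore estimated to give about 14000 nM in this assay, likely between 6000 nM and 35000 nM.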

Compound 4, half-maximal inhibitory concentration: 65000 nM
Beside the measured number, compound 4's estimate is 4.6-fold (0.67 log units) below it; the whole stated range lies below it.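

In this assay, the iodo change on the core of compound 3 gives a 1.8-fold higher number from compound 3 to compound 4 (0.25 log units; within the scatter), so the step seen on the core of compound 1 did not carry over to this core: the same change on two cores in this assay, a 2.6-fold lower number (0.41 log units; beyond the scatter) from compound 1 to compound 2 and a 1.8-fold higher number (0.25 log units; within the scatter) from compound 3 to compound 4, 4.6-fold (0.67 log units) apart, beyond the scatter of two such steps The chloro change tells the same story from the other side, giving a 3.4-fold higher number from compound 2 to compound 4 (0.54 log units; beyond the scatter) on the core of compound 2, and this step does not match the one on the core of compound 1: the same change on two cores in this assay, a 1.3-fold lower number (0.13 log units; within the scatter) from compound 1 to compound 3 and a 3.4-fold higher number (0.54 log units; beyond the scatter) from compound 2 to compound 4, 4.6-fold (0.67 log units) apart, beyond the scatter of two such steps Within these four compounds, the iodo and chloro changes therefore do not add up independently, but this rests on a single pair of cores for each change and shows neither why the steps differ nor how either change would behave on any other core.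

On these data alone, it remains open whether bromo, fluoro or methoxy in place of the iodo on the phenyl ring would also give steps that differ between the two cores. As far as these compounds go, it is equally open whether an amine or a carboxylic acid in that place would do so.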